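The source may hold more compounds than are shown below. What is called first, only, known or untested is meant among the compounds shown, and "the series" means these compounds.

Compound 2, with the structure `Cn1c(-c2ccc(NC(=O)CSc3nc4cc(Cl)ccc4o3)cc2)nc(-c2ccccc2)c1-c1ccccc1`, gives 2.4% in a functional assay on MCF7 cells (Homo sapiens) for cytotoxicity, read by MTT assay, with a stated time of 24 h, tested at 0.64 ug/mL; on this read-out higher numbers stand for a stronger effect at the one concentration tested and lower numbers for a weaker effect. Within the data shown here, its only measured companion is compound 1, built as `Cn1c(-c2ccc(NC(=O)CCl)cc2)nc(-c2ccccc2)c1-c1ccccc1`, which in this assay gives 3.4%, and the two values lie close together: the step of a number 1 percentage points lower from compound 1 to compound 2 (within the scatter) is a small one. Compound 2 is thus at the lower end of the two numbers at hand, but not separated from compound 1 by more than the ordinary spread of this kind of measurement.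

The unmeasured compound 3 has the structure `Cc1ccc2oc(SCC(=O)Nc3ccc(-c4nc(-c5ccccc5)c(-c5ccccc5)n4C)cc3)nc2c1`. It differs from compound 2 in one place: methyl in place of chloro on an aromatic carbon. Among the measured compounds shown here, no measured pair changes a substituent on that fused aromatic ring, so the only step in hand, the replacement of the chloro on the saturated chain carbon by the whole (5-chloro-1,3-benzoxazol-2-yl)sulfanyl group, bears on it only loosely, and that step a number 1 percentage points lower from compound 1 to compound 2 (within the scatter) moved nothing beyond the scatter. Both measured compounds sit at the low end of the read-out. The expected step is therefore a number 0.6 percentage points higher from compound 2 to compound 3 (within the scatter), nothing beyond the scatter, and compound 3 is estimated at 3% in this assay, between 0% and 13%.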

Compound 3, a percentage reported as activity, at one concentration (the size of the read-out at that concentration, not a potency): 1.1%
Compound 3: the middle estimate sits 1.9 percentage points above what was measured; measured number inside the range.
By their numbers in this assay, from the lowest: compounds 3, 2 and 1 (each within the scatter of the next).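

Among these compounds, exchanging chloro for methyl on this aromatic carbon of the fused system is the first change at this place, and in this assay it gives a number 1.3 percentage points lower from compound 2 to compound 3 (within the scatter), so this swap of one heavy atom for another, neither counted as a hydrogen-bond donor or acceptor, does not separate the two compounds. The methyl form of the larger group, (5-methyl-1,3-benzoxazol-2-yl)sulfanyl, put in place of chloro on the saturated chain carbon bound to the carbonyl carbon, gives a number 2.3 percentage points lower from compound 1 to compound 3 (within the scatter), so it too stays within the scatter, as the chloro form of that group did. No outside information bears on this result, so nothing here accounts for these small steps.

From the compounds shown here alone, whether an amine or a carboxylic acid on that aromatic carbon, or a longer chain between the sulfur and the carbonyl, would move the read-out beyond the scatter remains open. Going by these compounds, all these numbers come from a single concentration, so how the compounds compare at other concentrations remains open as well.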